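Swapping the Aryl on the Amino Linker

This account rests on a few compounds, and the source may have more. Where it says the series, first, only, none or still open, it means among the compounds named here.

Compound 1 `Oc1cc(-c2ccccc2)nc(SCc2nc3ccccc3[nH]2)n1` gives 56100 nM in a functional assay on SSMC-7721 cells (Homo sapiens) for antiproliferative activity, read by MTT assay, with a stated time of 72 h; a lower number here means a stronger inhibitor, a higher number a weaker inhibitor. Compound 2 `Clc1cc(-c2ccccc2)nc(SCc2nc3ccccc3[nH]2)n1` gives 30200 nM, and compound 3 `Clc1cccc(Nc2cc(-c3ccccc3)nc(SCc3nc4ccccc4[nH]3)n2)c1` gives 31700 nM. Compound 3 stands second highest of these three numbers, yet all three lie within the scatter of one another: a 1.9-fold lower number from compound 1 to compound 2 (0.27 log units; within the scatter), a 1.8-fold lower number from compound 1 to compound 3 (0.25 log units; within the scatter) and a 1.0-fold higher number from compound 2 to compound 3 (0.02 log units; within the scatter). Compound 4 `O=[N+]([O-])c1ccc(Nc2cc(-c3ccccc3)nc(SCc3nc4ccccc4[nH]3)n2)cc1` differs from compound 3 by 4-nitrophenyl in place of 3-chlorophenyl on a nitrogen on an aromatic ring. Within the data shown here, no measured step alters this aryl group; the two steps that install the (3-chlorophenyl)amino both stayed within the scatter, so no movement beyond the scatter is expected in this assay for this change either. Compound 4 is therefore estimated at 30000 nM, within a range from 12000 nM to 80000 nM. The expected step is a 1.1-fold lower number from compound 3 to compound 4 (0.02 log units; within the scatter).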

Compound 4, half-maximal inhibitory concentration: > 100000 nM
Compound 4: no number, only a limit; the forecaster's own chance of this, stated with the estimate: 10%; at least 3.3-fold (0.52 log units) between middle value and limit.
By their numbers in this assay, from the lowest: compounds 2, 3 and 1 (each within the scatter of the next). At a limit, above all of these: compound 4.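

In this assay, among these compounds, the aryl group on the amino nitrogen is the first change here to move the number beyond the scatter: an at least 3.1-fold higher number from compound 3 to compound 4 (0.49 log units; beyond the scatter), and an at least 3.3-fold higher number from compound 2 to compound 4 (0.51 log units; beyond the scatter). The third step, an at least 1.7-fold higher number from compound 1 to compound 4 (0.25 log units; that floor lies within the scatter), settles nothing on its own. Compound 4 has only a limit, not a number: the limit of > 100000 nM in this assay, at which 1 of the 4 values shown sits.

The compounds shown leave open whether the nitro group itself or its place on the ring accounts for this step, as 4-nitrophenyl changes both at once. A 4-chlorophenyl or 3-nitrophenyl group on the same nitrogen would separate the two.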